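Extending the chain on a urea inhibitor of cholesterol acyltransferase

The source may hold more compounds than are shown below. What is called first, only, known or untested is meant among the compounds shown, and "the series" means these compounds.

Three ureas sharing one core differ only in the length of a straight chain on the aromatic ring. Compound 1 `CCCCCCCCc1ccc(NC(=O)Nc2c(C(C)C)cccc2C(C)C)cc1` gives 11 nM in an assay on isolated protein for inhibition of acyl-CoA:cholesterol acyltransferase (Oryctolagus cuniculus); on this read-out higher numbers stand for weaker inhibition and lower numbers for stronger inhibition. Compound 2 `CCCCCCc1ccc(NC(=O)Nc2c(C(C)C)cccc2C(C)C)cc1` gives 26 nM in this assay, and compound 3 `CCCCc1ccc(NC(=O)Nc2c(C(C)C)cccc2C(C)C)cc1` gives 29 nM, the highest number of the three; compound 3 and compound 2 lie within the scatter of each other, as a 1.1-fold higher number from compound 2 to compound 3 (0.05 log units; within the scatter) shows, while a 2.6-fold higher number from compound 1 to compound 3 (0.42 log units; beyond the scatter) lies beyond it.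

Compound 4 `CCCCCCCCCCCc1ccc(NC(=O)Nc2c(C(C)C)cccc2C(C)C)cc1` has not been measured. It differs from compound 3 by heptyl in place of hydrogen on a saturated chain carbon, four bonds along the chain from an aromatic carbon. The step that bears on this is the shortening from compound 1 to compound 3, a 2.6-fold higher number from compound 1 to compound 3 (0.42 log units; beyond the scatter), which shows that a longer chain gave a lower number; the step of a 2.4-fold higher number from compound 1 to compound 2 (0.37 log units; beyond the scatter) points the same way. Compound 4 carries an even longer chain than compound 1, so a lower number than that of compound 3 is expected, of size a 3.6-fold lower number from compound 3 to compound 4 (0.56 log units; beyond the scatter). The estimate for compound 4 is 8 nM, with a range from 3 nM to 25 nM.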

Compound 4, half-maximal inhibitory concentration: 9 nM
Estimate against measurement, compound 4: 1.1-fold (0.05 log units) below; measured number inside the range.
By their numbers in this assay, from the lowest: compounds 4 and 1 (each within the scatter of the next); then compounds 2 and 3 (each within the scatter of the next).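

Lengthening the chain still lowers the number against the two shorter ureas, as both heptyl on the chain of compound 3 (a 3.2-fold lower number from compound 3 to compound 4 (0.51 log units; beyond the scatter)) and pentyl on the chain of compound 2 (a 2.9-fold lower number from compound 2 to compound 4 (0.46 log units; beyond the scatter)) show. What is new lies at the long end: a further propyl, eight bonds along the chain from an aromatic carbon, gives no change that can be told from the scatter (a 1.2-fold lower number from compound 1 to compound 4 (0.09 log units; within the scatter)). The four compounds therefore fall into two pairs, compounds 2 and 3 with the higher numbers and compounds 1 and 4 with the lower, and the extra length of compound 4 brings no further drop.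

Nothing shown here bears on why the number changes with chain length. Going by these compounds, whether a longer chain still would keep the number this low, and how an amine or a carboxylic acid at the chain end would fare, stays open.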